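Swapping chloro for bromo on the benzyl group

A few compounds are considered here, and "the series" means these few. Any claim that something is new, unique, unknown or untested is made for them only; others in the source may bear on it.

Measured so far:
compound 1 `O=c1c(OCc2ccccc2Cl)c(-c2ccccc2)oc2cc(O)cc(O)c12`: > 100000 nM
compound 2 `O=c1c(OCc2ccccc2Br)c(-c2ccccc2)oc2cc(O)cc(O)c12`: 12000 nM
compound 3 `O=c1c(OCc2ccc(Cl)cc2)c(-c2ccccc2)oc2cc(O)cc(O)c12`: 36000 nM

These compounds share one core and differ only in the halogenated benzyl group. In an ADME assay on Huh-5-2 cells (Homo sapiens) for cytotoxicity, read by WST assay, with a stated time of 3 days (on this read-out higher numbers stand for lower toxicity in this test and lower numbers for higher toxicity in this test), compound 1 reaches only a limit of the test, > 100000 nM. Compound 2 gives 12000 nM. The change bromo in place of chloro on an aromatic carbon made a step of an at least 8.3-fold lower number from compound 1 to compound 2 (0.92 log units; beyond the scatter). Compound 1 sets only a bound on the size of that step because of the limit of > 100000 nM in this assay, at which 1 of the 3 values shown sits. Compound 3 gives 36000 nM, and its core differs from that of compound 1 by 4-chlorophenyl in place of 2-chlorophenyl on a saturated chain carbon bound to an oxygen on an aromatic ring. Compound 4 `O=c1c(OCc2ccc(Br)cc2)c(-c2ccccc2)oc2cc(O)cc(O)c12` is not yet measured; it differs from compound 3 by bromo in place of chloro on an aromatic carbon. This is the same kind of change as from compound 1 to compound 2, but the place differs: there the halogen sits ortho to a large group, here para to a large group. For compound 4 a step of a 2.4-fold lower number from compound 3 to compound 4 (0.38 log units; beyond the scatter) is expected, resting on the drop seen at an at least 8.3-fold lower number from compound 1 to compound 2 (0.92 log units; beyond the scatter), kept smaller since the place is not the same. Compound 4 is estimated at 15000 nM, between 5000 nM and 45000 nM.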

Compound 4, half-maximal cytotoxic concentration: 2000 nM
Compound 4: middle estimate off by 7.5-fold (0.88 log units), on the high side, outside the stated range (below it).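

In this assay, bromo in place of chloro again points toward higher toxicity in this test, with an 18-fold lower number from compound 3 to compound 4 (1.26 log units; beyond the scatter), so the direction of the change holds on both cores. Changing the group itself gives a 6.0-fold lower number from compound 2 to compound 4 (0.78 log units; beyond the scatter) for 4-bromophenyl in place of 2-bromophenyl, and an at least 50-fold lower number from compound 1 to compound 4 (1.69 log units; beyond the scatter) for 4-bromophenyl in place of 2-chlorophenyl. The size of the change is a separate matter, and these compounds do not show that it carries over: the same change on two cores in this assay, an at least 8.3-fold lower number (0.92 log units; beyond the scatter) from compound 1 to compound 2 and an 18-fold lower number (1.26 log units; beyond the scatter) from compound 3 to compound 4; the limit leaves it open whether they differ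

The compounds shown cover only chloro and bromo on the benzyl group. They leave open whether the trend would extend to iodo or fluoro, and how a methoxy group or an amine in the same place would behave.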